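A new group on the amide-type nitrogen

The source may report more compounds than this note shows. Statements on the series, on what has been measured and on what is new or still open speak of the compounds shown alone.

Values so far in a functional assay on MDA-MB-231 cells (Homo sapiens) for cytotoxicity, read by MTT assay, with a stated time of 48 h; on this read-out higher numbers stand for weaker inhibition and lower numbers for stronger inhibition
- compound 1 `O=C(NCCCCC(c1ccc(F)cc1)c1ccc(F)cc1)Nc1ccc(I)cc1` gives 11800 nM
- compound 2 `O=C(NCCCCC(c1ccc(F)cc1)c1ccc(F)cc1)Nc1cccc(Cl)c1` gives 5070 nM
- compound 3 `O=C(NCCCCC(c1ccc(F)cc1)c1ccc(F)cc1)Nc1ccc(Cl)c(C(F)(F)F)c1` gives 3150 nM

Compound 3 stands level with its nearest neighbour (a 1.6-fold lower number from compound 2 to compound 3 (0.21 log units; within the scatter)) and clearly apart from the furthest one (a 3.7-fold lower number from compound 1 to compound 3 (0.57 log units; beyond the scatter)). Compound 4 (`Cc1cc(Cl)ccc1NC(=O)NCCCCC(c1ccc(F)cc1)c1ccc(F)cc1`) brings a single swap, 4-chloro-2-methylphenyl in place of 4-chloro-3-(trifluoromethyl)phenyl on an amide-type nitrogen. Going by the values given here, all the measured steps are swaps at this same nitrogen. The two that leave 4-iodophenyl were modest (a 2.3-fold lower number from compound 1 to compound 2 (0.37 log units; beyond the scatter) and a 3.7-fold lower number from compound 1 to compound 3 (0.57 log units; beyond the scatter)), and the remaining one stayed small (a 1.6-fold lower number from compound 2 to compound 3 (0.21 log units; within the scatter)). Among the compounds with values here, no measured compound carries the methyl group, so these steps are only a rough guide. Compound 2, which also lacks trifluoromethyl, gives 5070 nM in this assay and suggests a slight lean toward a higher number, though no change beyond the scatter is expected. The expected move is a 1.4-fold higher number from compound 3 to compound 4 (0.15 log units; within the scatter) and remains an estimate. For compound 4 the estimated value is 4500 nM with an expected range from 2000 nM to 10000 nM in this measurement.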

Compound 4, half-maximal inhibitory concentration: > 20000 nM
Compound 4: a limit, no number (the forecaster's own chance of this, stated with the estimate: 4%); middle value at least 4.4-fold (0.64 log units) away from the limit.
By their numbers in this assay, from the lowest: compounds 3 and 2 (each within the scatter of the next); then compound 1. At a limit, above all of these: compound 4.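

The reading for compound 4 in this assay is a limit and not a number: the limit of > 20000 nM in this assay, at which 1 of the 4 values shown sits. Even so, an at least 6.3-fold higher number from compound 3 to compound 4 (0.80 log units; beyond the scatter) and an at least 3.9-fold higher number from compound 2 to compound 4 (0.59 log units; beyond the scatter) both lie beyond the scatter, which shows that exchanging one substituted phenyl group for another on this amide-type nitrogen can produce a larger loss of inhibition than any step among the earlier compounds. The comparison with the remaining compound is less clear: an at least 1.6-fold higher number from compound 1 to compound 4 (0.22 log units; that floor lies within the scatter), and this floor does not set compound 4 apart from compound 1.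

This swap removes trifluoromethyl and adds methyl at once, and the compounds shown cannot tell which of these changes matters. As far as these compounds go, how a phenyl group carrying an amine or a carboxylic acid would behave on this nitrogen also remains open.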